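Turning One Ring Stereocentre Back in a Shared Core

The compounds below may be only part of what the source reports. "The series", "measured", "known", "first", "only" and "open" are said of these compounds alone.

Compound 1 `N=C(N)NCCC[C@H]1NC(=O)CC(=O)N[C@@H](CC(=O)O)C(=O)N[C@@H](Cc2ccccc2)CNC1=O` carries a guanidine side chain, a carboxylic acid side chain and a benzyl side chain on its core. In an assay on K562 cells for inhibition of integrin alpha-5/beta-1 (Homo sapiens), with a stated time of 30 min (on this read-out higher numbers stand for weaker inhibition and lower numbers for stronger inhibition), compound 1 gives 4700 nM. Compound 2 `N=C(N)NCCC[C@@H]1NC(=O)CC(=O)N[C@H](CC(=O)O)C(=O)N[C@@H](Cc2ccccc2)CNC1=O` has the same atoms and bonds, with two stereocentres at saturated ring carbons drawn the other way round. For compound 2 this assay reports only a limit, > 100000 nM. Compound 3 `N=C(N)NCCC[C@H]1NC(=O)CC(=O)N[C@H](CC(=O)O)C(=O)N[C@H](Cc2ccccc2)CNC1=O` likewise differs from compound 1 at two ring stereocentres. For compound 3 this assay again reports only a limit, > 100000 nM. Inverting two centres thus gives an at least 21-fold higher number from compound 1 to compound 2 (1.32 log units; beyond the scatter) and an at least 21-fold higher number from compound 1 to compound 3 (1.32 log units; beyond the scatter), while a step that the two limits leave unreadable from compound 2 to compound 3 because both values are limits (the limit of > 100000 nM in this assay, at which 2 of the 3 values shown sit). Compound 4 `N=C(N)NCCC[C@H]1NC(=O)CC(=O)N[C@H](CC(=O)O)C(=O)N[C@@H](Cc2ccccc2)CNC1=O` differs from compound 3 in one place: the two compounds have the same atoms and bonds; at least one stereo element is drawn with a configuration in one of them and without one in the other: 1 of 4 stereo elements differ; a stereocentre at a saturated ring carbon is drawn R in compound 3 and S in compound 4. Within the data shown here, this returns that centre to the configuration of compound 1, so compound 4 differs from compound 1 at a single ring stereocentre, the one it shares with compounds 2 and 3. Compounds 2 and 3 both reached only the limit. The step expected here is an at least 1.2-fold lower number from compound 3 to compound 4 (0.09 log units; that floor lies within the scatter). Compound 4 is therefore expected to sit at or near the limit as well, with an estimate of 80000 nM and a range from 10000 nM to 300000 nM.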

Compound 4, half-maximal inhibitory concentration: > 100000 nM
Compound 4 gave a limit, no number; the forecaster's own chance of this, stated with the estimate: 70%; middle value at least 1.2-fold (0.09 log units) away from the limit.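

A single ring stereocentre inverted, with the other stereocentres left as drawn, is enough to give an at least 21-fold higher number from compound 1 to compound 4 (1.32 log units; beyond the scatter) in this assay. Compounds 2 and 3 each carried two inverted ring stereocentres relative to compound 1, and they left open whether one inversion alone would push the value to the limit, whereas compound 4 shows that at this position it does. Returning one centre of compound 3 to the configuration found in compound 1 gives no readable gain, and the steps among compounds 2, 3 and 4 cannot be read: the limit of > 100000 nM in this assay, at which 3 of the 4 values shown sit.

From the compounds shown here alone, how far the true values of compounds 2, 3 and 4 lie beyond this limit stays unknown, and with it whether a second inverted centre costs anything further. The compounds shown also leave open whether this position is as sensitive to inversion when the carboxylic acid sits on a longer chain, or when an amine takes the place of the guanidine.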